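Notes on the ring amine nitrogen substituent

This account rests on a few compounds, and the source may have more. Where it says the series, first, only, none or still open, it means among the compounds named here.

In a functional assay on MGC-803 cells (Homo sapiens) for antiproliferative activity, read by CCK-8 assay, with a stated time of 72 h, tested at 2 uM (on this read-out lower numbers stand for a weaker effect and higher numbers for a stronger effect at the one concentration tested), compound 1 `N#Cc1ccc(N2CCN(C(=S)SCc3ccc(C(=O)Nc4ccccc4N)cc3)CC2)cc1` gives 34.5%. Compound 2 `Nc1ccccc1NC(=O)c1ccc(CSC(=S)N2CCN(Cc3cccnc3)CC2)cc1` gives 37.7% in this assay, and the two values lie within the scatter of each other, as the step of a number 3.2 percentage points higher from compound 1 to compound 2 (within the scatter) shows. Compound 3 `Nc1ccccc1NC(=O)c1ccc(CSC(=S)N2CCN(C3CCCCC3)CC2)cc1` differs from compound 2 by cyclohexyl in place of (pyridin-3-yl)methyl on an amine nitrogen in a ring. Going by the values given here, only the step from compound 1 to compound 2 bears on this change, and it stayed within the scatter, so no step beyond the scatter is expected in this assay. The expected step is a number 1.7 percentage points lower from compound 2 to compound 3 (within the scatter). Compound 3 is therefore estimated to give 36%, with a range of 22% to 50%.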

Compound 3, a percentage reported as inhibition, at one concentration (the size of the read-out at that concentration, not a potency): 16.9%
Compound 3: the middle estimate sits 19.1 percentage points above what was measured, and the stated range ends above it.
By their numbers in this assay, from the lowest: compound 3; then compounds 1 and 2 (each within the scatter of the next).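

Cyclohexyl in place of (pyridin-3-yl)methyl gives a number 20.8 percentage points lower from compound 2 to compound 3 (beyond the scatter), and cyclohexyl in place of 4-cyanophenyl gives a number 17.6 percentage points lower from compound 1 to compound 3 (beyond the scatter). This position therefore does respond to the substituent in this assay, which the earlier pair did not show: among these three compounds, the two groups carrying an aromatic ring stay within the scatter of each other, and the non-aromatic ring of carbon only gives the lowest number. Nothing available explains this difference.

As far as these compounds go, it remains open whether an unsubstituted benzyl group on this nitrogen would fall with compound 2 or with compound 3, and where a short alkyl chain would fall.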